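Ethylsulfanyl in place of ethoxy on compound 1

This account rests on a few compounds, and the source may have more. Where it says the series, first, only, none or still open, it means among the compounds named here.

Compound 1 `CCOc1ccc(C2C(C3CC3)C(=O)N2c2cc(OC)c(OC)c(OC)c2)cc1` carries a cyclopropyl on a saturated ring carbon of the shared core. In a functional assay on MCF7 cells (Homo sapiens) for inhibition, read by resazurin assay, with a stated time of 72 h (a lower number here means a stronger inhibitor, a higher number a weaker inhibitor), compound 1 gives 131 nM, the highest number among the three measured compounds. Compound 2 `CCOc1ccc(C2C(O)C(=O)N2c2cc(OC)c(OC)c(OC)c2)cc1` gives 7 nM in this assay, and compound 3 `C=CC1C(=O)N(c2cc(OC)c(OC)c(OC)c2)C1c1ccc(OCC)cc1` gives 14 nM. The steps away from compound 1 are a 19-fold lower number from compound 1 to compound 2 (1.27 log units; beyond the scatter) and a 9.4-fold lower number from compound 1 to compound 3 (0.97 log units; beyond the scatter); between the two lower values the step is a 2.0-fold higher number from compound 2 to compound 3 (0.30 log units; within the scatter).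

Compound 4 `CCSc1ccc(C2C(C3CC3)C(=O)N2c2cc(OC)c(OC)c(OC)c2)cc1` differs from compound 1 in one place: ethylsulfanyl in place of ethoxy on an aromatic carbon. Within the data shown here, none of the measured steps touches this part of the molecule; all three concern the substituent on the saturated ring carbon, and the ethoxy group is held constant across compounds 1, 2 and 3. Among the measured compounds shown here, there is thus no measured step that bears on the change, and no direction can be read from the data. The expectation is a step of a 1.0-fold lower number from compound 1 to compound 4 (0.00 log units; within the scatter), within the scatter, around the value of compound 1. Compound 4 is expected to give 130 nM, with a range from 45 nM to 400 nM that reflects the absence of any bearing precedent.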

Compound 4, half-maximal inhibitory concentration: 606 nM
Compound 4: the middle estimate sits 4.7-fold (0.67 log units) below what was measured; measured number above the stated range.
By their numbers in this assay, from the lowest: compounds 2 and 3 (each within the scatter of the next); then compound 1; then compound 4.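

The position on the aromatic carbon, para to a large group, responds to change: with the cyclopropyl held constant, ethylsulfanyl in place of ethoxy gives in this assay a 4.6-fold higher number from compound 1 to compound 4 (0.67 log units; beyond the scatter) and so moves the number beyond the scatter. Among these compounds, until now, the only measured steps concerned the substituent on the saturated ring carbon, so this is the first reading of the aromatic side of the series, and it shows that the ethoxy group cannot be exchanged here without a measurable loss. The two groups have the same counts of heavy atoms, hydrogen-bond donors and hydrogen-bond acceptors and differ in oxygen against sulfur, yet nothing available accounts for the step, so the difference stays an observation without an explanation.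

The compounds shown leave open whether the same exchange costs as much when hydroxy or vinyl replaces the cyclopropyl, since ethylsulfanyl appears here only with the cyclopropyl. They also leave open how this position answers to other groups, such as methoxy, a longer chain like butoxy, or an amine.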